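Ethyl on the aromatic nitrogen of compound 2

A few compounds are considered here, and "the series" means these few. Any claim that something is new, unique, unknown or untested is made for them only; others in the source may bear on it.

In a functional assay on K562 cells (Homo sapiens) for inhibition, read by trypan blue exclusion, with a stated time of 72 h (on this read-out lower numbers stand for stronger inhibition and higher numbers for weaker inhibition), compound 2 `O=c1[nH]c2nc(Nc3ccc4[nH]ccc4c3)ncc2cc1S(=O)(=O)c1ccc(F)cc1F` gives 15000 nM, the higher of the two numbers available, while compound 1 `CCCn1c(=O)c(S(=O)(=O)c2ccc(F)cc2F)cc2cnc(Nc3ccc4[nH]ccc4c3)nc21` gives 1000 nM. Compound 3 `CCn1c(=O)c(S(=O)(=O)c2ccc(F)cc2F)cc2cnc(Nc3ccc4[nH]ccc4c3)nc21` differs from compound 2 in one place, with ethyl in place of hydrogen on an aromatic nitrogen. Compound 1 carries propyl on that nitrogen. Among the compounds with values here, the only measured step bearing on this change, hydrogen in place of propyl, is a 15-fold higher number from compound 1 to compound 2 (1.18 log units; beyond the scatter), which is large and beyond the scatter. Ethyl in compound 3 runs the opposite way, replacing that hydrogen with an alkyl chain, so a large step toward a lower number is expected in this assay, though this rests on a single pair. The estimated step is a 10-fold lower number from compound 2 to compound 3 (1.00 log units; beyond the scatter). For compound 3 the estimated value is 1500 nM, with an expected range of 500 nM to 5000 nM.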

Compound 3, half-maximal inhibitory concentration: 750 nM
Estimate against measurement, compound 3: 2.0-fold (0.30 log units) above, within the range that was stated.
By their numbers in this assay, from the lowest: compounds 3 and 1 (each within the scatter of the next); then compound 2.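

In this assay, ethyl on the aromatic nitrogen brings a 20-fold lower number from compound 2 to compound 3 (1.30 log units; beyond the scatter) and so gives a second case of the large shift that propyl alone had shown, seen there as a 15-fold higher number from compound 1 to compound 2 (1.18 log units; beyond the scatter) in the other direction. Going from propyl to ethyl, with hydrogen in place of methyl on a saturated chain carbon, gives a 1.3-fold lower number from compound 1 to compound 3 (0.12 log units; within the scatter) and leaves the two chains indistinguishable, so among these compounds the large difference lies between the hydrogen and an alkyl chain, and not between these two chain lengths. Nothing available explains this difference.

As far as these compounds go, whether methyl on that nitrogen would suffice stays open, as does whether a longer chain such as butyl, or a chain ending in an amine or a carboxylic acid, would hold the lower number. The compounds also leave open whether the same holds with another group in place of the (2,4-difluorophenyl)sulfonyl group.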